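Replacing the 4-methylpiperazin-1-yl group of compound 2

The source may hold more compounds than are shown below. What is called first, only, known or untested is meant among the compounds shown, and "the series" means these compounds.

In an ADME assay on HepG2 cells (Homo sapiens) for inhibition, with a stated time of 48 h (on this read-out higher numbers stand for an effect only at larger amounts of compound and lower numbers for an effect already at smaller amounts), compound 1 (`CC(C(=O)N1CCC2(CC1)CC2)N1CCN(S(=O)(=O)c2ccc(C(C)(C)C)cc2)CC1`) gives > 40000 nM, which is a limit and not a number. Compound 2 (`CC(C(=O)N1CCN(C)CC1)N1CCN(S(=O)(=O)c2ccc(C(C)(C)C)cc2)CC1`) gives > 40000 nM, again only a limit. Compound 2 therefore has no readable value, and the data show only (the limit of > 40000 nM in this assay, at which 2 of the 2 values shown sit). Compound 3 (`CC(C(=O)N1CCc2ccccc2C1C)N1CCN(S(=O)(=O)c2ccc(C(C)(C)C)cc2)CC1`) carries 1-methyl-1,2,3,4-tetrahydroisoquinolin-2-yl in place of 4-methylpiperazin-1-yl on a carbonyl carbon. Within the data shown here, the only measured step at this place is a step that the two limits leave unreadable from compound 1 to compound 2, so it supplies no size to carry over. Among the measured compounds shown here, with that step as the sole guide, only a modest change is expected in this assay, and a limit is again the likeliest result. The expected step is an at least 1.3-fold lower number from compound 2 to compound 3 (0.12 log units; that floor lies within the scatter), with at most a slight lean toward lower numbers. For compound 3 the estimated value is 30000 nM, with an expected range from 12000 nM to 60000 nM.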

Compound 3, half-maximal effective concentration: 28000 nM
Estimate against measurement, compound 3: 1.1-fold (0.03 log units) above; measured number inside the range.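

Compound 3 gives this position its first readable number, 28000 nM in this assay. Earlier the series showed only a limit: the limit of > 40000 nM in this assay, at which 2 of the 3 values shown sit. Putting 1-methyl-1,2,3,4-tetrahydroisoquinolin-2-yl on the carbonyl carbon gives an at least 1.4-fold lower number from compound 2 to compound 3 (0.15 log units; that floor lies within the scatter), and the comparison with the group of compound 1 gives an at least 1.4-fold lower number from compound 1 to compound 3 (0.15 log units; that floor lies within the scatter). As far as these compounds go, both steps are floors resting on a limit, so their full size stays unknown, and what they add is a direction for this change rather than a measured distance.

The compounds shown leave open whether the lower number goes with the six-membered aromatic ring or with the methyl of the entering group, and the step from compound 1 to compound 2 cannot be read. They also do not tell how 1,2,3,4-tetrahydroisoquinolin-2-yl without its methyl, or a morpholin-4-yl group, would read on this carbonyl carbon.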